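Urea series: bromo for chloro on the distal aryl ring

The source may hold more compounds than are shown below. What is called first, only, known or untested is meant among the compounds shown, and "the series" means these compounds.

Measured compounds, in an ADME assay on MCF-10A cells (Homo sapiens) for inhibition, with a stated time of 48 h; on this read-out higher numbers stand for weaker inhibition and lower numbers for stronger inhibition:
- compound 1, `O=C(Nc1ccc(Cl)cc1)N1CCC[C@H]1c1nc(-c2ccccc2)no1`, gives > 50000 nM, a limit of the assay.
- compound 2, `O=C(Nc1ccc(Br)cc1)N1CCC[C@H]1c1nc(-c2ccccc2)no1`, gives > 50000 nM, likewise only a limit.
- compound 3, `O=C(Nc1ccc(Cl)cc1)N1CCC[C@H]1c1nc(-c2ccc(Cl)cc2)no1`, gives > 50000 nM, again a limit.

Among the compounds with values here, all three values sit at the same limit, (the limit of > 50000 nM in this assay, at which 3 of the 3 values shown sit), so no step among them can be read: the change bromo in place of chloro on an aromatic carbon gave a step that the two limits leave unreadable from compound 1 to compound 2, and the change chloro in place of hydrogen on an aromatic carbon gave a step that the two limits leave unreadable from compound 1 to compound 3.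

Compound 4, `O=C(Nc1ccc(Cl)cc1)N1CCC[C@H]1c1nc(-c2ccc(Br)cc2)no1`, remains to be measured. It differs from compound 3 by bromo in place of chloro on an aromatic carbon, the same change that turns compound 1 into compound 2, at a place worded identically in both cases. The cores of compound 1 and compound 3 differ by chloro in place of hydrogen on an aromatic carbon.

From compound 3 to compound 4 a step that the limit leaves unreadable from compound 3 to compound 4 is expected, the expectation resting on (the limit of > 50000 nM in this assay, at which 3 of the 3 values shown sit), where every measured value in this assay sits. Compound 4 is therefore expected to give about 60000 nM in this assay, with a range of 30000 nM to 120000 nM, most likely reported once more only as a limit.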

Compound 4, half-maximal inhibitory concentration: > 50000 nM
Compound 4: a limit, no number; the forecaster's own chance of this, stated with the estimate: 85%; the middle value lies beyond the limit too.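

In this assay compound 4 gives > 50000 nM, which is a limit and not a number. Within the data shown here, no step from compound 1 or compound 3 to compound 4 can be read: the limit of > 50000 nM in this assay, at which 4 of the 4 values shown sit. The compounds shown leave open how large any of these halogen changes is in this assay, and whether any urea of this series reaches a measurable value there.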